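The source may report more compounds than this note shows. Statements on the series, on what has been measured and on what is new or still open speak of the compounds shown alone.

Measured in a functional assay on CCRF-CEM cells (Homo sapiens) for cytotoxicity; on this read-out higher numbers stand for lower toxicity in this test and lower numbers for higher toxicity in this test:
compound 1 `O=C1c2ccccc2NS(=O)(=O)N1COCCO`: > 200 ug/mL
compound 2 `CC(=O)OCCOCN1C(=O)c2ccccc2NS1(=O)=O`: > 200 ug/mL
compound 3 `O=C1c2ccccc2N(COCCO)S(=O)(=O)N1Cc1ccccc1`: 89 ug/mL.

The value of compound 1, > 200 ug/mL, is a limit of this assay, not a number. The value of compound 2, > 200 ug/mL, is likewise a limit. Among the measured compounds shown here, compound 3 gives the only number, 89 ug/mL.

The change from compound 1 to compound 2, (acetyl in place of hydrogen on an oxygen on a saturated carbon), made a step that the two limits leave unreadable from compound 1 to compound 2 whose size cannot be read, both values standing at the limit of > 200 ug/mL in this assay, at which 2 of the 3 values shown sit.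

Compound 4 `CC(=O)OCCOCN1c2ccccc2C(=O)N(Cc2ccccc2)S1(=O)=O` is not yet measured. It differs from compound 3 by acetyl in place of hydrogen on an oxygen on a saturated carbon, the same change at a place described in the same words. How the core of compound 3 differs from that of compound 1 is not broken down here.

For the measured compounds named here, the one measured instance of this change gives no readable size, so the expectation rests on compound 3 and its value 89 ug/mL. Compound 4 is expected to give 100 ug/mL, estimated between 45 ug/mL and 200 ug/mL. The step of a 1.1-fold higher number from compound 3 to compound 4 (0.05 log units; within the scatter) is accordingly expected to be small.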

Compound 4, half-maximal cytotoxic concentration: 103 ug/mL
The estimate for compound 4 lay 1.0-fold (0.01 log units) below the measured number; measured number inside the range.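

In this assay acetyl in place of hydrogen on the oxygen gives a 1.2-fold higher number from compound 3 to compound 4 (0.06 log units; within the scatter) on the core of compound 3, so there the change from 2-hydroxyethyl to 2-acetoxyethyl stays within the scatter. On the core of compound 1 the same change cannot be read, because compound 1 and compound 2 both stand at a limit and not at a number: the limit of > 200 ug/mL in this assay, at which 2 of the 4 values shown sit. This leaves one readable instance of the change, so it does not show that the step carries over from one core to the other.

The compounds shown leave open how this assay responds when the terminal hydroxy is replaced by an amine or a carboxylic acid. They also leave open what a chain longer than 2-hydroxyethyl would give on either core.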